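A few compounds are considered here, and "the series" means these few. Any claim that something is new, unique, unknown or untested is made for them only; others in the source may bear on it.

Compound 2, `Cc1ccc(CS/C(=C/c2c[nH]c3ccc(Cl)cc23)C(=O)c2ccc(Cl)cc2)cc1`, gives the lowest number of the three measured compounds in a functional assay on DU-145 cells (Homo sapiens) for inhibition, read by trypan blue exclusion, with a stated time of 96 h; on this read-out lower numbers stand for stronger inhibition of growth and higher numbers for weaker inhibition of growth: compound 2 gives 1000 nM. Compound 1, `Cc1ccc(CS(=O)(=O)/C(=C/c2ccc(S(C)(=O)=O)cc2)C(=O)c2ccc(Br)cc2)cc1`, gives 10000 nM in this assay, and compound 3, `CN(C)c1ccc(/C=C(\C(=O)c2ccc(Br)cc2)S(=O)(=O)Cc2ccc(F)cc2)cc1`, gives 50000 nM; both of these lie beyond the usual scatter from compound 2. Among the compounds with values here, compound 1 and compound 3 each differ from compound 2 in more than one place, so no single step can be drawn from them.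

Compound 4, `CSc1ccc(/C=C(/SCc2ccc(C)cc2)C(=O)c2ccc(Cl)cc2)cc1`, has not yet been measured. It differs from compound 2 by one change: 4-(methylsulfanyl)phenyl in place of 5-chloro-1H-indol-3-yl on a double-bonded chain carbon bound to a double-bonded chain carbon. The hydrogen-bond donor of the group that leaves is lost, and a hydrogen-bond acceptor arrives with the group that enters. The two measured compounds that carry a six-membered carbon ring at this place, compound 1 and compound 3, both give weaker growth inhibition than compound 2, so a step toward weaker inhibition, beyond the scatter, is expected for this change in this assay: the estimated step is a 5.0-fold higher number from compound 2 to compound 4 (0.70 log units; beyond the scatter). Compound 4 is expected to give about 5000 nM in this assay, within a range from 1000 nM to 30000 nM.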

Compound 4, concentration for 50% growth inhibition: 25000 nM
Compound 4: middle estimate off by 5.0-fold (0.70 log units), on the low side; the measured number falls inside the stated range.
By their numbers in this assay, from the lowest: compound 2; then compound 1; then compounds 4 and 3 (each within the scatter of the next).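

Within the data shown here, this is the first step here that changes one place alone, and in this assay replacing 5-chloro-1H-indol-3-yl with 4-(methylsulfanyl)phenyl gives a 25-fold higher number from compound 2 to compound 4 (1.40 log units; beyond the scatter), a large loss of growth inhibition. With the rest of the molecule unchanged, the group on this double-bonded chain carbon clearly matters in this pair. No measurement at hand explains the size of this step.

The change removes a hydrogen-bond donor, adds a hydrogen-bond acceptor and replaces two aromatic rings with one, so the compounds shown cannot separate these differences. As far as these compounds go, it also remains open whether an unsubstituted 1H-indol-3-yl group would keep the growth inhibition of compound 2, or whether a phenyl ring carrying an amine at this place would recover any of it.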